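Aryloxypropyl side chain: halogen shift on two cores

The compounds below may be only part of what the source reports. "The series", "measured", "known", "first", "only" and "open" are said of these compounds alone.

Compound 1 `NC1=NC2(CCOCC2)N(OCCCOc2ccccc2Cl)C(N)=N1` and compound 3 `NC1=NC2(CCSCC2)N(OCCCOc2ccccc2Cl)C(N)=N1` carry the same 2-chlorophenoxy-bearing side chain on two different cores; the difference between the two cores is not broken down here. In an assay on isolated protein for inhibition of Dihydrofolate reductase (Homo sapiens), read by spectrophotometry, using NADPH, with stated times of 5 s and 6 min, tested at 50 uM (a lower number here means a weaker effect, a higher number a stronger effect of the compound at the concentration tested), compound 1 gives 88.2%, and compound 3 gives 89.6%, two numbers within the usual scatter of each other. Compound 2 `NC1=NC2(CCOCC2)N(OCCCOc2cccc(Br)c2)C(N)=N1` keeps the core of compound 1 and differs from it by 3-bromophenyl in place of 2-chlorophenyl on an oxygen on a saturated carbon. In this assay compound 2 gives 85.8%, so the step of a number 2.4 percentage points lower from compound 1 to compound 2 (within the scatter) is flat. Compound 4 `NC1=NC2(CCSCC2)N(OCCCOc2cccc(Br)c2)C(N)=N1` is still to be measured; it keeps the core of compound 3 and differs from it by 3-bromophenyl in place of 2-chlorophenyl on an oxygen on a saturated carbon, which is the same change, made at the same place, as that from compound 1 to compound 2. Compound 4 is therefore expected to stay close to compound 3, an expectation that rests on the flat step a number 2.4 percentage points lower from compound 1 to compound 2 (within the scatter). The expected step is a number 2.6 percentage points lower from compound 3 to compound 4 (within the scatter). Compound 4 is estimated to give 87% in this assay, with a likely range from 80% to 93%.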

Compound 4, a percentage reported as inhibition, at one concentration (the size of the read-out at that concentration, not a potency): 86.5%
Compound 4: the middle estimate sits 0.5 percentage points above what was measured; the measured number falls inside the stated range.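

In this assay the exchange of 2-chlorophenyl for 3-bromophenyl on the core of compound 3 gives a number 3.1 percentage points lower from compound 3 to compound 4 (within the scatter) and matches the earlier step on the core of compound 1: the same change on two cores in this assay, a number 2.4 percentage points lower (within the scatter) from compound 1 to compound 2 and a number 3.1 percentage points lower (within the scatter) from compound 3 to compound 4, 0.7 percentage points apart, within the scatter of two such steps

Within these two pairs, the exchange therefore carries from one core to the other with no visible difference in this read-out. Among the compounds shown here, the finding rests on only two pairs, each read at one concentration, so it does not establish that the two groups are equal in potency, nor that the exchange would stay flat on any other core or that any other change at this place would carry over in the same way.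

The compounds shown leave open how an unsubstituted phenyl, a phenyl bearing an amine or a carboxylic acid, or a longer chain would behave on these two cores. They also leave open whether the flat steps would remain flat at a lower test concentration.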